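The source may hold more compounds than are shown below. What is called first, only, known or untested is meant among the compounds shown, and "the series" means these compounds.

Compound 1 `Cc1cc(NC(=O)C2CC2)ccc1N1CCC(N2CCCC2C)C1`: 17.7 nM
Compound 2 `Cc1cc(N2CCC(N3CCCC3C)C2)ccc1NC(=O)C1CCCO1`: 7.34 nM

Both compounds were tested in an assay on CHO cells for displacement of a labelled ligand from histamine receptor H3 (Macaca mulatta); on this read-out lower numbers stand for stronger inhibition and higher numbers for weaker inhibition. In this assay compound 1 gives 17.7 nM, the higher of the two numbers, while compound 2 gives 7.34 nM, a gap that lies beyond the usual scatter. Within the data shown here, no single-change step between these two compounds has been worked out, so their values are taken only as they stand.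

Compound 3 `Cc1cc(NC(=O)C2CCOCC2)ccc1N1CCC(N2CCCC2C)C1` has not yet been measured. It differs from compound 1 in one place: oxan-4-yl in place of cyclopropyl on a carbonyl carbon. Because compound 2 gives 7.34 nM, a modest move toward a lower number is expected for compound 3 in this assay, though one that may stay within the scatter. The expected step is a 1.6-fold lower number from compound 1 to compound 3 (0.21 log units; within the scatter). Compound 3 is estimated at 11 nM, within a range from 4.5 nM to 27 nM.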

Compound 3, inhibition constant: 17 nM
Beside the measured number, compound 3's estimate is 1.5-fold (0.19 log units) below it, within the range that was stated.
By their numbers in this assay, from the lowest: compound 2; then compounds 3 and 1 (each within the scatter of the next).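

Replacing cyclopropyl with oxan-4-yl on the carbonyl carbon gives a 1.0-fold lower number from compound 1 to compound 3 (0.02 log units; within the scatter) in this assay, so the two compounds read alike. At this position, then, a ring of 6 heavy atoms with 1 hydrogen-bond acceptor can stand in place of a ring of 3 heavy atoms with none, and the number stays within the scatter. No measurement shown here explains this result.

This is a single step between two groups, so it sets no general rule for the position. How an open chain such as methoxyethyl, a ring carrying an amine, or a group bearing a carboxylic acid would read on the same carbonyl carbon remains an open question, as does whether oxan-4-yl would give a similar result on a different core.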